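From azidomethyl to 4-chlorobutyl on the carbonyl

The source may hold more compounds than are shown below. What is called first, only, known or untested is meant among the compounds shown, and "the series" means these compounds.

In a functional assay on KYSE-450 cells (Homo sapiens) for inhibition, read by MTT assay, with a stated time of 48 h (a lower number here means a stronger inhibitor, a higher number a weaker inhibitor), compound 3 `COc1ccc(CN(C(=O)CN=[N+]=[N-])c2cc(OC)c(OC)c(OC)c2)cc1O` gives 160 nM. Compound 1 `COc1ccc(CN(C(=O)C(C)Br)c2cc(OC)c(OC)c(OC)c2)cc1O`, with 1-bromoethyl on the carbonyl carbon, gives 160 nM, and compound 2 `COc1ccc(CN(C(=O)C=C(C)C)c2cc(OC)c(OC)c(OC)c2)cc1O`, with 2-methylprop-1-en-1-yl there, gives 280 nM. Compound 3 therefore stands level with compound 1 and within the scatter of compound 2. The measured steps are no change at the digits printed from compound 1 to compound 3 (within the scatter), a 1.8-fold lower number from compound 2 to compound 3 (0.24 log units; within the scatter) and a 1.8-fold higher number from compound 1 to compound 2 (0.24 log units; within the scatter).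

The next compound is compound 4 `COc1ccc(CN(C(=O)CCCCCl)c2cc(OC)c(OC)c(OC)c2)cc1O`. Its change from compound 3 is 3-chloropropyl in place of azido on a saturated chain carbon bound to a carbonyl carbon, which, cut one bond further out, reads azidomethyl to 4-chlorobutyl: 3-chloropropyl in place of azido on a saturated chain carbon bound to a carbonyl carbon. All three measured steps bear on this change, since each exchanges the group on the same carbonyl carbon. Among the measured compounds shown here, none of them stepped beyond the scatter, but no measured compound carries the 4-chlorobutyl group, so they guide the size of the step only loosely. A step within the scatter is therefore expected in this assay, with a slight lean towards a higher number. The expected move is a 1.6-fold higher number from compound 3 to compound 4 (0.19 log units; within the scatter). For compound 4 the estimated value is 250 nM, with an expected range from 90 nM to 700 nM.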

Compound 4, half-maximal inhibitory concentration: 770 nM
Compound 4: the middle estimate sits 3.1-fold (0.49 log units) below what was measured, and the stated range ends below it.
By their numbers in this assay, from the lowest: compounds 1, 3 and 2 (each within the scatter of the next); then compound 4.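

In this assay, among the compounds shown here, the group on the carbonyl carbon produces steps beyond the scatter for the first time: 3-chloropropyl in place of azido gives a 4.8-fold higher number from compound 3 to compound 4 (0.68 log units; beyond the scatter), the exchange from 2-methylprop-1-en-1-yl gives a 2.8-fold higher number from compound 2 to compound 4 (0.44 log units; beyond the scatter), and the exchange from 1-bromoethyl gives a 4.8-fold higher number from compound 1 to compound 4 (0.68 log units; beyond the scatter). This position therefore does not take every exchange alike: azidomethyl, 1-bromoethyl and 2-methylprop-1-en-1-yl remain within the scatter of one another, while compound 4, with 4-chlorobutyl, stands apart from all three as the weaker inhibitor. Nothing available here accounts for this separation.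

Going by these compounds, whether the higher number belongs to the length of the chain or to the chlorine at its end remains open, and a plain butyl group or a 4-hydroxybutyl group on the carbonyl carbon would separate the two. On these data alone, how a shorter 2-chloroethyl group or an aminomethyl group would stand against azidomethyl and 4-chlorobutyl also remains open.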